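A few compounds are considered here, and "the series" means these few. Any claim that something is new, unique, unknown or untested is made for them only; others in the source may bear on it.

Measured compounds:

Compound 1, `NC(=O)c1ccc(-c2cnc3ccc(-c4cccc(S(=O)(=O)C5CC5)c4)nn23)cc1`. In a physicochemical assay for solubility, at pH 6.5 (on this read-out higher numbers stand for higher solubility and lower numbers for lower solubility), compound 1 reaches only the assay limit of < 5000 nM.
Compound 2, `C[S+]([O-])c1cccc(-c2ccc3ncc(-c4ccc(C(N)=O)cc4)n3n2)c1`. In this assay compound 2 likewise gives the limit < 5000 nM.
Compound 3, `CS(=O)(=O)c1cccc(-c2ccc3ncc(-c4cncc(S(C)(=O)=O)c4)n3n2)c1`. In this assay compound 3 also gives the limit < 5000 nM.

Compound 2 therefore stands at a limit, not at a number, and so do the other two measured compounds: the limit of < 5000 nM in this assay, at which 3 of the 3 values shown sit. Among the measured compounds shown here, the only single-point change among them, a step that the two limits leave unreadable from compound 1 to compound 2, is unreadable for that reason, so no measured step gives a direction or a size in this assay for this series.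

The new compound 4, `C[S+]([O-])c1ccc(-c2cnc3ccc(-c4cccc([S+](C)[O-])c4)nn23)cc1`, differs from compound 2 by a group of 3 heavy atoms (1 carbon, 1 oxygen, 1 sulfur; no ring) in place of a group of 3 heavy atoms (1 carbon, 1 nitrogen, 1 oxygen; no ring), on an aromatic carbon. Nothing measured bears on this exchange, and with every shown value sitting at the limit the expectation for compound 4 can only lean on where compound 2 stands. Compound 4 is expected to stay in the same region, with the step that the limit leaves unreadable from compound 2 to compound 4 estimated as not readable beyond the scatter. For compound 4 the estimate in this assay is 3000 nM, with a range from 500 nM to 12000 nM, and a reported limit rather than a number is the more likely outcome.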

Compound 4, solubility: 192000 nM
Compound 4: the middle estimate sits 64-fold (1.81 log units) below what was measured, and the stated range ends below it.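

In this assay, the place on the six-membered aromatic ring of carbon only, para to a large group, proves able to move the read-out: carbamoyl leaving in favour of the group of 3 heavy atoms (1 carbon, 1 oxygen, 1 sulfur) gives an at least 38-fold higher number from compound 2 to compound 4 (1.58 log units; beyond the scatter). Compound 2 is a limit and not a number, so the true size of this step may be larger than the printed figure. Compound 4 is the only compound shown that gives a number rather than a limit, which makes this the first readable step in the series and sets it apart from the rest: the limit of < 5000 nM in this assay, at which 3 of the 4 values shown sit.

From the compounds shown here alone, one exchange cannot separate the departure of carbamoyl, with its hydrogen-bond donor, from the arrival of the entering group, and it remains open which of the two goes with the step. Also open, going by these compounds, is how this place responds to a nitrile, a carboxylic acid or an amine, and whether the same exchange gives a step of this size when the other group on the core changes.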